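Working notes: compound 3, methyl in place of hydrogen

The compounds below may be only part of what the source reports. "The series", "measured", "known", "first", "only" and "open" are said of these compounds alone.

Measured so far in a functional assay on the whole organism (blood, strain Wistar albino) for inhibition, with Rattus norvegicus as the target, read by colorimetric assay, with stated times of 15 min and 90 min, at a dose of 20 mg/kg by the oral route; a lower number here means less inhibition, a higher number more inhibition at the dose given (going by the name of the read-out):
compound 1, `O=C(NC1CCCCC1)NS(=O)(=O)c1ccc(-n2nc(-c3ccccc3)ccc2=O)cc1`: 52.1%
compound 2, `O=C(NC1CCCCC1)NS(=O)(=O)c1ccc(-n2nc(-c3ccc(Cl)cc3)ccc2=O)cc1`: 59%

Among the compounds with values here, of the two numbers, that of compound 2 is the larger, yet the only measured step, a number 6.9 percentage points higher from compound 1 to compound 2 (within the scatter), lies within the scatter, so the two values are not told apart. The structural change behind that step was chloro in place of hydrogen on an aromatic carbon of the phenyl group attached to the shared core.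

Compound 3, `Cc1cc(-c2ccc(=O)n(-c3ccc(S(=O)(=O)NC(=O)NC4CCCCC4)cc3)n2)ccc1Cl`, follows on from compound 2 by methyl in place of hydrogen on an aromatic carbon. Within the data shown here, no measured step involves a methyl group, so the one step that bears on the question is a number 6.9 percentage points higher from compound 1 to compound 2 (within the scatter), which adds a small group to the same ring and stays within the scatter. On that basis a methyl group entering on the same ring is expected to move the read-out little, with no direction beyond the scatter to be claimed.

Compound 3 is therefore estimated at 60% in this assay, with a range from 47% to 73%, which means an expected step of a number 1 percentage points higher from compound 2 to compound 3 (within the scatter).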

Compound 3, a percentage reported as inhibition, in the whole organism at one dose (the size of the read-out at that dose, not a potency): 62.1%
For compound 3 the middle estimate is 2.1 percentage points below the measured one, within the range that was stated.
By their numbers in this assay, from the lowest: compounds 1, 2 and 3 (each within the scatter of the next).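

In this assay, within the data shown here, methyl on an aromatic carbon, ortho to a chloro group and meta to a large group, gives a number 3.1 percentage points higher from compound 2 to compound 3 (within the scatter) and so shows that this carbon of the 4-chlorophenyl group can carry a methyl with no step that stands clear of the scatter. The full replacement of phenyl by 4-chloro-3-methylphenyl gives a number 10 percentage points higher from compound 1 to compound 3 (within the scatter) and likewise stays within the scatter, so chloro and methyl together do not separate compound 1 from compound 3 in this read-out at the single dose. No measurement at hand accounts for these steps.

Still open, from the compounds shown here alone, is whether another group on this same aromatic carbon, such as an amine, a carboxylic acid or a longer chain, would give a step beyond the scatter in this assay at this dose. Also open is how methyl on this carbon reads without the chloro group, as the compounds shown carry the methyl only together with it.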